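Pentyl on selenium: cytotoxicity notes on four compounds

This account rests on a few compounds, and the source may have more. Where it says the series, first, only, none or still open, it means among the compounds named here.

Compound 2 `[SeH]c1nc(NCc2ccccc2)c2ccccc2n1` and compound 1 `CCCCC[Se]c1nc(NCc2ccccc2)c2ccccc2n1` share one core; how that core differs from the core of compound 3 `Nc1nc([SeH])nc2ccccc12` is not broken down here. In a functional assay on CCRF-CEM cells (Homo sapiens) for cytotoxicity, read by MTT assay, with a stated time of 72 h (a higher number here means that more compound is tolerated, a lower number that less compound is tolerated), compound 2 gives only a limit, > 100000 nM. Compound 1 likewise gives only a limit in this assay, > 100000 nM. The change between them, (pentyl in place of hydrogen on a selenium), thus leaves a step that the two limits leave unreadable from compound 2 to compound 1 because both values sit at the limit of > 100000 nM in this assay, at which 2 of the 3 values shown sit.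

Within the data shown here, compound 3 is the one compound with a number in this assay, 79100 nM. Compound 4 `CCCCC[Se]c1nc(N)c2ccccc2n1` arises from compound 3 by pentyl in place of hydrogen on a selenium, the same change at the same place. The step of a 1.1-fold higher number from compound 3 to compound 4 (0.06 log units; within the scatter) is expected to be small, since compound 3 already gives 79100 nM. Compound 4 is estimated at 90000 nM, between 30000 nM and 300000 nM, with a fair chance that only a limit is returned.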

Compound 4, concentration lethal to 50% of the cells: > 100000 nM
Compound 4: only a limit was reported (the forecaster's own chance of this, stated with the estimate: 55%); at least 1.1-fold (0.04 log units) between middle value and limit.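

In this assay, going by these compounds, pentyl in place of hydrogen on a selenium gives an at least 1.2-fold higher number from compound 3 to compound 4 (0.10 log units; that floor lies within the scatter), which is a floor only, so the true size of the step stays unknown. The same change on the core of compound 1 cannot be read, nor can the step between compound 1 and compound 4, so the data neither confirm nor refute that the change carries from one core to the other. Most readings stop at a single limit: the limit of > 100000 nM in this assay, at which 3 of the 4 values shown sit.

On these data alone, it remains open whether any group on the selenium gives a number rather than a limit on the core of compound 1. A longer chain such as octyl, or a carboxylic acid in place of pentyl on the selenium, would bear on this.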